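A Bromophenyl Group in Place of Cyclopropyl

The source may hold more compounds than are shown below. What is called first, only, known or untested is meant among the compounds shown, and "the series" means these compounds.

Compound 1 `O=c1cc(NC2CC2)cc(-c2ccccc2)o1`: > 30 uM
Compound 2 `COc1ccc(Nc2cc(C3CCCCC3)oc(=O)c2)cc1`: 4.39 uM
Compound 3 `COc1ccccc1Nc1cc(-c2ccccc2)oc(=O)c1`: 0.49 uM

All three compounds were tested in a functional assay on KBVIN cells (Homo sapiens) for cytotoxicity, read by MTT assay, with a stated time of 72 h; a lower number here means that less compound is needed, a higher number that more compound is needed for the effect. Compound 1 stands at the limit of > 30 uM in this assay, at which 1 of the 3 values shown sits, so its entry is a limit and not a number. Compound 4 `O=c1cc(Nc2ccc(Br)cc2)cc(-c2ccccc2)o1` keeps the core of compound 1 and changes one group: 4-bromophenyl in place of cyclopropyl on a nitrogen on an aromatic ring. In words, 4-bromophenyl replaces cyclopropyl on a nitrogen on an aromatic ring.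

The two measured compounds with numbers offer the best guide, as both carry an aromatic ring on that nitrogen. Compound 2 gives 4.39 uM, with a different group elsewhere on the core. Compound 3 gives 0.49 uM, and it shares the phenyl group of compound 4. Among the compounds with values here, with only three compounds, this is a thin basis for any forecast. Even so, a large step of an at least 12-fold lower number from compound 1 to compound 4 (1.07 log units; beyond the scatter) is expected in this assay, towards a lower number and beyond the usual scatter. The estimate for compound 4 is 2.5 uM, with an expected range of 0.6 uM to 10 uM.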

Compound 4, concentration for half-maximal effect: 0.24 uM
Compound 4: middle estimate off by 10-fold (1.02 log units), on the high side; the measured number lies below the stated range.
By their numbers in this assay, from the lowest: compound 4; then compound 3; then compound 2. At a limit, above all of these: compound 1.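

Before this result, no two compounds differed in one place only, so the group on this nitrogen could not be judged alone. In this assay, with the phenyl group on the core left unchanged, 4-bromophenyl in place of cyclopropyl gives an at least 120-fold lower number from compound 1 to compound 4 (2.09 log units; beyond the scatter), which shows that this one place can by itself move the read-out far beyond the scatter. Compound 1 carries a limit and not a number: the limit of > 30 uM in this assay, at which 1 of the 4 values shown sits.

Whether the step comes from the aromatic ring or from the bromine on it stays open, as an unsubstituted phenyl on this nitrogen is not among the compounds shown. On these data alone, how a longer chain such as n-butyl, or a ring bearing a carboxylic acid or an amine, would behave at this nitrogen also stays open.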